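Imidazole for pyrrole on a cholesterol-acylating enzyme's urea inhibitor

The source may report more compounds than this note shows. Statements on the series, on what has been measured and on what is new or still open speak of the compounds shown alone.

Measured so far:
compound 1, `Cc1cc(C)c(NC(=O)N(Cc2cccc(-n3cccc3)c2)C2CCCCCC2)c(C)c1`: 0.17 mg/kg
compound 2, `Cc1cc(C)c(NC(=O)N(Cc2ccc(-c3ccnn3C)cc2)C2CCCCCC2)c(C)c1`: < 1 mg/kg

Among the measured compounds shown here, compound 1 is the only compound with a full number in a functional assay on a cell-free system (plasma) with sterol O-acyltransferase, Soat (Rattus norvegicus) as the target; a higher number here means that more compound is needed for the effect, a lower number that less compound is needed; compound 1 gives 0.17 mg/kg there. For compound 2 the value < 1 mg/kg in this assay is a limit, not a number, as noted in the limit of < 1 mg/kg in this assay, at which 1 of the 2 values shown sits. Compound 3, `Cc1cc(C)c(NC(=O)N(Cc2cccc(-c3c[nH]cn3)c2)C2CCCCCC2)c(C)c1`, has not been measured. It differs from compound 1 by 1H-imidazol-4-yl in place of 1H-pyrrol-1-yl on an aromatic carbon. For the measured compounds named here, no measured pair shows what such a swap does, so the step of a 1.8-fold higher number from compound 1 to compound 3 (0.25 log units; within the scatter) is expected to stay within the scatter or lean a little toward needing more compound. Compound 3 is therefore estimated at 0.3 mg/kg, between 0.1 mg/kg and 1 mg/kg.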

Compound 3, dose for half-maximal effect: < 1 mg/kg
Compound 3: a limit, no number; the forecaster's own chance of this, stated with the estimate: 15%; the middle value does not contradict the limit.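

Compound 3 gives only a limit, not a number, so the step from compound 1 to compound 3 cannot be read: the limit of < 1 mg/kg in this assay, at which 2 of the 3 values shown sit. As far as these compounds go, whether 1H-imidazol-4-yl in place of 1H-pyrrol-1-yl changes the dose needed stays open.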